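A Second Chloro on the Same Aromatic Ring

The compounds below may be only part of what the source reports. "The series", "measured", "known", "first", "only" and "open" are said of these compounds alone.

Of the compounds shown here, two have been measured so far. Compound 1 `COc1cc2c(Oc3ccc(NC(=O)c4nn(-c5ccccc5)c(=O)cc4C)cc3F)ccnc2cc1OCCCN1CCCCC1` gives 160 nM in a functional assay on MKN-45 cells (Homo sapiens) for inhibition, read by MTT assay, with a stated time of 72 h; on this read-out higher numbers stand for weaker inhibition and lower numbers for stronger inhibition. Compound 2 `COc1cc2c(Oc3ccc(NC(=O)c4nn(-c5ccc(Cl)cc5)c(=O)cc4C)cc3F)ccnc2cc1OCCCN1CCCCC1`, in which a chloro replaces a hydrogen on an aromatic carbon, gives 230 nM in this assay. The step of a 1.4-fold higher number from compound 1 to compound 2 (0.16 log units; within the scatter) shows that this first chloro left the number essentially unchanged. Compound 2 therefore stands alongside compound 1, its number and that of compound 1 lying within the scatter of each other.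

Compound 3 `COc1cc2c(Oc3ccc(NC(=O)c4nn(-c5ccc(Cl)cc5Cl)c(=O)cc4C)cc3F)ccnc2cc1OCCCN1CCCCC1` carries one further change: chloro in place of hydrogen on an aromatic carbon. Among the compounds with values here, the only measured step that bears on this is the earlier one, a 1.4-fold higher number from compound 1 to compound 2 (0.16 log units; within the scatter), which added a chloro to the same aromatic ring and stayed within the scatter. With no step beyond the scatter from an added chloro on this ring in hand, a second chloro is expected to behave much the same way. For compound 3 the expected step is no change at the digits printed from compound 2 to compound 3 (within the scatter), that is, no movement beyond the scatter. Compound 3 is accordingly estimated at 230 nM in this assay, with a range from 100 nM to 550 nM.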

Compound 3, half-maximal inhibitory concentration: 80 nM
The estimate for compound 3 lay 2.9-fold (0.46 log units) above the measured number, outside the stated range (below it).
By their numbers in this assay, from the lowest: compounds 3, 1 and 2 (each within the scatter of the next, the first and the last beyond it).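

In this assay, adding a chloro to this ring does not always leave the number in place: the chloro that enters ortho to a large group and meta to the existing chloro group gives a 2.9-fold lower number from compound 2 to compound 3 (0.46 log units; beyond the scatter), whereas the earlier addition gave a 1.4-fold higher number from compound 1 to compound 2 (0.16 log units; within the scatter). The gain is limited, however, since the full change from phenyl to 2,4-dichlorophenyl gives a 2.0-fold lower number from compound 1 to compound 3 (0.30 log units; within the scatter), so the second chloro stands out against the 4-chlorophenyl compound but does not separate the dichloro compound from the plain phenyl one. Nothing measured here gives a reason for the step from 4-chlorophenyl to 2,4-dichlorophenyl.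

The compounds shown leave open whether this step belongs to chloro itself, and a methyl group, a methoxy group or an amine in the place of the second chloro would test that. They also leave open whether a single chloro at this new place, on a ring without the first chloro, would give a similar number, so the two chloro groups cannot yet be told apart as separate contributors.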